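The source may report more compounds than this note shows. Statements on the series, on what has been measured and on what is new or still open speak of the compounds shown alone.

Compound 1, `C(=C/c1ccccc1)\CN1CCN(CCN(Cc2ccccc2)c2ccccn2)CC1`, gives 6.1 in an assay on HEK293 cells for inhibition of sodium-dependent dopamine transporter (Homo sapiens); on this read-out lower numbers stand for lower potency and higher numbers for higher potency (the scale is a negative logarithm).
Compound 2, `C(=C/c1ccccc1)\CN1CCN(CCN(Cc2ccccc2)c2ccccc2)CC1`, gives 6.74 in this assay.
Compound 3, `O=C(CCCN1CCN(CCCc2ccccc2)CC1)N(Cc1ccccc1)c1ccccc1`, gives 7.12 in this assay.

Compound 3 stands highest of the three; its nearest neighbour is compound 2, and compound 1 lies furthest from it. How the core of compound 3 differs from that of compound 2 is not broken down here. Within the pair that shares a core, the step of a number 0.64 log units lower from compound 2 to compound 1 (beyond the scatter) is a modest drop, and it comes with the change (pyridin-2-yl in place of phenyl on an amine nitrogen).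

Compound 4, `O=C(CCCN1CCN(CCCc2ccccc2)CC1)N(Cc1ccccc1)c1ccccn1`, has not yet been measured in this assay. It differs from compound 3 by the change (pyridin-2-yl in place of phenyl on an amide-type nitrogen). Among the measured compounds shown here, this is the same kind of change as the one from compound 2 to compound 1, but not the same: in the measured pair the ring sits on an amine nitrogen whose other neighbours are two saturated chain carbons, whereas in compound 4 it sits on an amide-type nitrogen whose other neighbours are a carbonyl carbon and a saturated chain carbon. Because the earlier step of a number 0.64 log units lower from compound 2 to compound 1 (beyond the scatter) was a drop beyond the scatter, a similar drop is expected here, with the different surroundings of the nitrogen adding uncertainty. The step from compound 3 to compound 4 is estimated at a number 0.62 log units lower from compound 3 to compound 4 (beyond the scatter). Compound 4 is therefore expected to give about 6.5, most likely between 6 and 7.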

Compound 4, logarithm of the reciprocal of the active concentration, log(1/C): 6.61
Beside the measured number, compound 4's estimate is 0.11 log units below it, and the stated range covers the measured number.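

In this assay, putting pyridin-2-yl in place of phenyl on an amide-type nitrogen gives a modest drop, a number 0.51 log units lower from compound 3 to compound 4 (beyond the scatter). Set beside the same change on the amine nitrogen of the other core, the step keeps its direction, and the two sizes cannot be told apart: the same change on two cores in this assay, a number 0.64 log units lower (beyond the scatter) from compound 2 to compound 1 and a number 0.51 log units lower (beyond the scatter) from compound 3 to compound 4, 0.13 log units apart, within the scatter of two such steps This shows that, in these two matched pairs, the drop carries from one core to the other even though the surroundings of the nitrogen differ, but two pairs do not establish a rule for other cores in the series, and they give no explanation for the drop.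

The compounds shown leave open whether the drop is specific to pyridin-2-yl or would also appear with another ring on the same nitrogen, such as a thienyl or cyclohexyl group. They also leave open whether the step would stay the same if the benzyl group on that nitrogen gave way to a methyl group, or if the linker to the piperazine-bearing part of the core were a shorter or longer chain.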